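Trifluoromethyl on the anilide ring of the nitrofuran series

A few compounds are considered here, and "the series" means these few. Any claim that something is new, unique, unknown or untested is made for them only; others in the source may bear on it.

Two members of the series are measured. Compound 1 `O=C(Nc1ccc(-c2cnc3cc(Cl)ccn23)cc1)c1ccc([N+](=O)[O-])o1` gives 1700 nM in a functional assay on AGS cells (Homo sapiens) for antiproliferative activity, read by CCK-8 assay, with a stated time of 72 h; a lower number here means a stronger inhibitor, a higher number a weaker inhibitor. Within the data shown here, compound 2 `COc1ccn2c(-c3ccc(NC(=O)c4ccc([N+](=O)[O-])o4)cc3)cnc2c1` gives 720 nM in the same assay, the lowest of the two numbers; the only measured step, a 2.4-fold lower number from compound 1 to compound 2 (0.37 log units; beyond the scatter), is a methoxy in place of chloro on the shared core. Compound 3 `COc1ccn2c(-c3ccc(NC(=O)c4ccc([N+](=O)[O-])o4)c(C(F)(F)F)c3)cnc2c1` differs from compound 2 by trifluoromethyl in place of hydrogen on an aromatic carbon, on an aromatic carbon of a six-membered carbon-only ring, ortho to a large group and meta to a large group. Among the measured compounds shown here, no measured step touches that ring; the single step from compound 1 to compound 2 sits on the core and does not bear on this change. With nothing to anchor a direction, no step beyond the scatter is expected, with a wide range on either side. Compound 3 is therefore estimated at 750 nM (range 250 nM to 2500 nM), the expected step being a 1.0-fold higher number from compound 2 to compound 3 (0.02 log units; within the scatter).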

Compound 3, half-maximal inhibitory concentration: 710 nM
Estimate against measurement, compound 3: 1.1-fold (0.02 log units) above; the measured number falls inside the stated range.
By their numbers in this assay, from the lowest: compounds 3 and 2 (each within the scatter of the next); then compound 1.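

The anilide ring now has its first measured step: in this assay the change gives a 1.0-fold lower number from compound 2 to compound 3 (0.01 log units; within the scatter) and so stays within the scatter. At this aromatic carbon, ortho to a large group and meta to a large group, trifluoromethyl in place of hydrogen therefore leaves the read-out indistinguishable from that of compound 2, whereas the earlier step beyond the scatter, a 2.4-fold lower number from compound 1 to compound 2 (0.37 log units; beyond the scatter) on the shared core, said nothing about this ring. Nothing at hand bears on why this replacement leaves the number where it is.

As far as these compounds go, whether an amine, a carboxylic acid or a longer chain at this carbon would also stay within the scatter remains open. Also open, from the compounds shown here alone, is whether trifluoromethyl here would give a similar result with chloro in place of methoxy on the core, as in compound 1.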